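Isopropyl for propanoyl: compound 3 to compound 4

The source may report more compounds than this note shows. Statements on the series, on what has been measured and on what is new or still open speak of the compounds shown alone.

In a functional assay on DLD-1 cells (Homo sapiens) for cytotoxicity, with a stated time of 48 h (a lower number here means a stronger inhibitor, a higher number a weaker inhibitor), compound 1 (`CCCCCOc1ccc2oc(/C=C/[S+](C)[O-])cc(=O)c2c1`) gives 6600 nM and compound 2 (`CC(C)CC(=O)Oc1ccc2oc(/C=C/[S+](C)[O-])cc(=O)c2c1`) gives 6100 nM in the same read-out. Compound 3 (`CCC(=O)Oc1ccc2oc(/C=C/[S+](C)[O-])cc(=O)c2c1`) gives 9000 nM and stands level with both, since its two steps, a 1.4-fold higher number from compound 1 to compound 3 (0.13 log units; within the scatter) and a 1.5-fold higher number from compound 2 to compound 3 (0.17 log units; within the scatter) are within the scatter. The remaining step, a 1.1-fold lower number from compound 1 to compound 2 (0.03 log units; within the scatter) is also within the scatter.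

Compound 4 (`CC(C)Oc1ccc2oc(/C=C/[S+](C)[O-])cc(=O)c2c1`) differs from compound 3 by isopropyl in place of propanoyl on an oxygen on an aromatic ring with isopropyl in place of propanoyl on an oxygen on an aromatic ring. For the measured compounds named here, no measured step makes this exact change. The closest is a 1.4-fold higher number from compound 1 to compound 3 (0.13 log units; within the scatter) where propanoyl replaces pentyl on the same oxygen, and it stays within the scatter. Across the three compounds, neither the chain nor the carbonyl has yet moved the number beyond the scatter, so no step beyond the scatter is expected in this assay. The expected change is small, an estimated 1.2-fold lower number from compound 3 to compound 4 (0.08 log units; within the scatter) within the scatter. The estimate for compound 4 is 7500 nM with an expected range of 3500 nM to 15000 nM in this read-out.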

Compound 4, half-maximal inhibitory concentration: 8000 nM
Estimate against measurement, compound 4: 1.1-fold (0.03 log units) below; the measured number falls inside the stated range.
By their numbers in this assay, from the lowest: compounds 2, 1, 4 and 3 (each within the scatter of the next).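

In this assay, the swap of propanoyloxy for isopropoxy takes the carbonyl off this oxygen on the aromatic ring and brings a branched chain onto it, yet a 1.1-fold lower number from compound 3 to compound 4 (0.05 log units; within the scatter) stays within the scatter. The same holds against the two larger groups at this place, with a 1.3-fold higher number from compound 2 to compound 4 (0.12 log units; within the scatter) and a 1.2-fold higher number from compound 1 to compound 4 (0.08 log units; within the scatter) also within the scatter, so isopropyl reads level with pentyl, isobutylcarbonyl and propanoyl here. No available evidence bears on why these groups read alike.

On these data alone, whether an amine, a carboxylic acid or a phenyl ring on this oxygen would move the number beyond the scatter remains open. As far as these compounds go, all four compounds share the remainder of the core, so it is also open whether this level reading holds once that remainder changes.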